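Compound 2 to compound 3: fluoro for methyl

A few compounds are considered here, and "the series" means these few. Any claim that something is new, unique, unknown or untested is made for them only; others in the source may bear on it.

Measured so far:
- compound 1 `Cc1c(NC(=O)C(C)Br)cccc1C(=O)NC(N)=O`: 480 nM
- compound 2 `Cc1ccc(NC(=O)C(C)Br)cc1C(=O)NC(N)=O`: > 20000 nM

All readings come from a functional assay on CCRF-CEM cells (Homo sapiens) for antiproliferative activity, read by trypan blue exclusion, with a stated time of 72 h; a lower number here means a stronger inhibitor, a higher number a weaker inhibitor. Compound 1 gives a measured number there, 480 nM.

Compound 2 stands at > 20000 nM, which is a limit of the assay and not a number. Going by the values given here, its exact standing is therefore unknown, and no step from it can be read as a measured size.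

The next compound is compound 3 `CC(Br)C(=O)Nc1ccc(F)c(C(=O)NC(N)=O)c1`. The change from compound 2 is fluoro in place of methyl on an aromatic carbon, ortho to a carbamoylcarbamoyl group and para to a ((1-bromoethyl)carbonyl)amino group.

Among the compounds with values here, no measured step covers this change. Within the data shown here, the only guide is that compound 1 at 480 nM shows a number can be reached with this side chain. A gain over compound 2 is expected, though only tentatively, and a second reading at the limit remains quite possible. The expected step is an at least 5.0-fold lower number from compound 2 to compound 3 (0.69 log units; beyond the scatter) in this assay, towards stronger inhibition. For compound 3 the estimated value is 4000 nM, with an expected range of 400 nM to 20000 nM.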

Compound 3, half-maximal inhibitory concentration: 520 nM
For compound 3 the middle estimate is 7.7-fold (0.89 log units) above the measured one, and the stated range covers the measured number.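

In this assay, compound 2 reads > 20000 nM, which is a limit of the assay and not a number. On the aromatic carbon ortho to the carbamoylcarbamoyl group and para to the ((1-bromoethyl)carbonyl)amino group, fluoro in place of methyl turns that limit into a measured reading, with an at least 38-fold lower number from compound 2 to compound 3 (1.58 log units; beyond the scatter), so this carbon is not closed to activity in this substitution pattern: with methyl the series sits at the limit, and with fluoro it gives a number. The step is a lower bound only, and its true size stays unread: the limit of > 20000 nM in this assay, at which 1 of the 3 values shown sits.

As far as these compounds go, whether the gain belongs to fluoro itself or simply to the removal of methyl remains open, and a hydrogen, chloro or methoxy on this same carbon would separate those two readings. Also open, from the compounds shown here alone, is how much of the reading in compound 3 depends on the bromo of the side chain, a question that a chloro in its place, or a plain propanoyl amide without any halogen, would address directly.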